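Hydroxy to methoxy on a pyrazole urea scaffold

This account rests on a few compounds, and the source may have more. Where it says the series, first, only, none or still open, it means among the compounds named here.

Among the compounds with values here, compound 1 `O=C(Nc1cccc(-n2cc(-c3ccncc3)c(-c3cc(O)cc(Cl)c3)n2)c1)Nc1ccc(Cl)c(C(F)(F)F)c1` sits at the high end of the two numbers measured so far: in a functional assay on IGROV-1 cells (Homo sapiens) for inhibition, read by sulforhodamine B assay, with a stated time of 48 h, tested at 1 uM (a lower number here means a stronger effect, a higher number a weaker effect of the compound at the concentration tested), compound 1 gives 113%, while compound 2 `O=C(Nc1cccc(-n2cc(-c3ccncc3)c(-c3cc(O)cc(Cl)c3)n2)c1)Nc1ccc(Cl)c(Cl)c1` gives 95%, the weaker signal belonging to compound 1. Within the data shown here, the only measured step, a number 18 percentage points lower from compound 1 to compound 2 (beyond the scatter), concerns a different part of the molecule. Compound 3 `COc1cc(Cl)cc(-c2nn(-c3cccc(NC(=O)Nc4ccc(Cl)c(C(F)(F)F)c4)c3)cc2-c2ccncc2)c1` differs from compound 1 by methyl in place of hydrogen on an oxygen on an aromatic ring. Among the measured compounds shown here, no measured step touches this oxygen, so the expectation is a step of about a number 8 percentage points lower from compound 1 to compound 3 (within the scatter), within the scatter. Compound 3 is therefore estimated at 105%, in a range from 85% to 125%.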

Compound 3, a percentage reported as activity, at one concentration (the size of the read-out at that concentration, not a potency): 87%
Estimate against measurement, compound 3: 18 percentage points above, within the range that was stated.
By their numbers in this assay, from the lowest: compounds 3 and 2 (each within the scatter of the next); then compound 1.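

Replacing hydroxy with methoxy on the 3-chloro-5-hydroxyphenyl ring shows that this oxygen matters in this assay, where the change gives a number 26 percentage points lower from compound 1 to compound 3 (beyond the scatter). The free hydroxy hydrogen is therefore not needed for the stronger effect at the concentration tested. No available measurement explains this shift. From the compounds shown here alone, whether an ethoxy group or a longer chain on this oxygen, or an amine in place of the hydroxy, would change the number remains open, as does whether methoxy would have a similar effect on compound 2 with its second chloro group.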